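The compounds below may be only part of what the source reports. "The series", "measured", "known", "first", "only" and "open" are said of these compounds alone.

Working notes on the series, read in a functional assay on DU-145 cells (Homo sapiens) for inhibition, read by trypan blue exclusion, with a stated time of 96 h (a lower number here means a stronger inhibitor of growth, a higher number a weaker inhibitor of growth), throughout. For the measured compounds named here, compound 3 (`Cc1ccc(CS/C(=C/c2ccc(C)s2)C(=O)c2ccc(Cl)cc2)cc1`) gives 50000 nM and stands level with compound 1 (`Cc1ccc(/C=C(/SCc2ccc(Cl)cc2)C(=O)c2ccc(Cl)cc2)s1`) at 50000 nM as the highest number so far. Compound 2 (`COc1ccccc1/C=C(/SCc1ccc(F)cc1)C(=O)c1ccc(Cl)cc1`) lies lower at 10000 nM in the same read-out.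

The next structure is compound 4 (`Cc1ccc(/C=C(/SCc2ccc(F)cc2)C(=O)c2ccc(Cl)cc2)s1`). The change from compound 3 is fluoro in place of methyl on an aromatic carbon as a swap of fluoro in place of methyl on an aromatic carbon, para to a large group, turning 4-methylbenzyl into 4-fluorobenzyl.

Going by the values given here, one measured step bears directly on this place: no change at the digits printed from compound 1 to compound 3 (within the scatter) for methyl in place of chloro. Compound 2 also carries 4-fluorobenzyl but differs from compound 4 elsewhere, so it only widens the range towards lower numbers. No step beyond the scatter is therefore expected in this assay here.

The expected move is a 1.3-fold lower number from compound 3 to compound 4 (0.10 log units; within the scatter) and would stay within the scatter. For compound 4 the estimate is 40000 nM with an expected range from 12000 nM to 70000 nM in this read-out.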

Compound 4, concentration for 50% growth inhibition: > 100000 nM
Compound 4: a limit, no number (the forecaster's own chance of this, stated with the estimate: 20%); middle value at least 2.5-fold (0.39 log units) from the limit.
By their numbers in this assay, from the lowest: compound 2; then compounds 1 and 3 (each within the scatter of the next). At a limit, above all of these: compound 4.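

Compound 4 gives a limit, not a number: the limit of > 100000 nM in this assay, at which 1 of the 4 values shown sits.

With 4-fluorobenzyl common to both compounds, the swap on the double-bonded chain carbon reads as an at least 10-fold higher number from compound 2 to compound 4 (1.00 log units; beyond the scatter), the only step shown that clears the scatter, so the clearest difference so far lies with 5-methylthiophen-2-yl against 2-methoxyphenyl rather than with the benzyl substituent. On the aromatic carbon para to a large group, the two steps are an at least 2.0-fold higher number from compound 3 to compound 4 (0.30 log units; that floor lies within the scatter) and an at least 2.0-fold higher number from compound 1 to compound 4 (0.30 log units; that floor lies within the scatter); with both floors inside the scatter, the limit does not separate fluoro from methyl or chloro there.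

From the compounds shown here alone, whether 2-methoxyphenyl gives a lower number alongside 4-methylbenzyl or 4-chlorobenzyl remains open. Also open, going by these compounds, is what an amine or a carboxylic acid on that aromatic carbon would give.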